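Cyclopentyl to Cyclohexylmethyl on the Aromatic Ether Oxygen

The source may hold more compounds than are shown below. What is called first, only, known or untested is meant among the compounds shown, and "the series" means these compounds.

Three compounds share one core and differ only in the group on an oxygen on an aromatic ring. In an assay on isolated protein for antagonist activity at Bile acid receptor (Homo sapiens), read by HTRF, with a stated time of 30 min (on this read-out higher numbers stand for weaker inhibition and lower numbers for stronger inhibition), compound 1 `CCc1cc(C(C)=O)c(OCc2cccc(C)c2)cc1OCCCCCC(C)(C)c1nnn[nH]1` gives 1200 nM, compound 2 `CCc1cc(C(C)=O)c(OC(C)c2ccccc2)cc1OCCCCCC(C)(C)c1nnn[nH]1` gives 1700 nM, and compound 3 `CCc1cc(C(C)=O)c(OC2CCCC2)cc1OCCCCCC(C)(C)c1nnn[nH]1` gives 3300 nM, the highest of the three numbers. Compound 4 `CCc1cc(C(C)=O)c(OCC2CCCCC2)cc1OCCCCCC(C)(C)c1nnn[nH]1` carries cyclohexylmethyl in place of cyclopentyl on an oxygen on an aromatic ring. Going by the values given here, two measured steps bear on this change: a 2.8-fold higher number from compound 1 to compound 3 (0.44 log units; beyond the scatter) and a 1.9-fold higher number from compound 2 to compound 3 (0.29 log units; within the scatter), both exchanging a group that holds a six-membered aromatic ring for the bare five-membered cyclopentyl. Compound 4 brings back a six-membered ring, now non-aromatic, joined through a methylene, so the number is expected to move back down modestly, with a 1.7-fold lower number from compound 3 to compound 4 (0.22 log units; within the scatter) expected to sit near the edge of the scatter. Compound 4 is thus estimated to give 2000 nM in this assay, with a range of 1000 nM to 4000 nM.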

Compound 4, half-maximal inhibitory concentration: 2900 nM
Compound 4: middle estimate off by 1.5-fold (0.16 log units), on the low side, within the range that was stated.
By their numbers in this assay, from the lowest: compounds 1, 2, 4 and 3 (each within the scatter of the next, the first and the last beyond it).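

In this assay the step of a 1.1-fold lower number from compound 3 to compound 4 (0.06 log units; within the scatter) shows that the larger cyclohexylmethyl does not set itself apart from cyclopentyl on this oxygen. The step of a 1.7-fold higher number from compound 2 to compound 4 (0.23 log units; within the scatter) leaves cyclohexylmethyl also level with 1-phenylethyl, whereas the step of a 2.4-fold higher number from compound 1 to compound 4 (0.38 log units; beyond the scatter) for cyclohexyl in place of 3-methylphenyl keeps compound 1 apart from both saturated groups, with compound 2 within the scatter of all the others. Nothing available here accounts for these results. Going by these compounds, whether an amine or a carboxylic acid on the cyclohexyl ring would change the number remains open, as does the effect of a longer chain between the oxygen and that ring.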